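This account rests on a few compounds, and the source may have more. Where it says the series, first, only, none or still open, it means among the compounds named here.

- Compound 1 `O=C1C=C(NC2CCCCC2)C(=O)c2c1nc1n2[C@H]2OC[C@@H](O)[C@H]2OC1`: > 8000 nM
- Compound 2 `O=C1C=C(Nc2ccccc2)C(=O)c2c1nc1n2[C@H]2OC[C@@H](O)[C@H]2OC1`: 1730 nM

Going by the values given here, in a functional assay on MGC-803 cells (Homo sapiens) for inhibition, read by sulforhodamine B assay (a lower number here means a stronger inhibitor, a higher number a weaker inhibitor), compound 2 gives 1730 nM, the only exact number so far. Compound 1 gives > 8000 nM, which is a limit of the assay and not a number. The next compound, compound 3 `O=C1C=C(Nc2ccc(I)cc2)C(=O)c2c1nc1n2[C@H]2OC[C@@H](O)[C@H]2OC1`, differs from compound 2 at the anilino group: iodo in place of hydrogen on an aromatic carbon. Iodo takes the place of hydrogen on an aromatic carbon, turning phenyl into 4-iodophenyl. Among the compounds with values here, only one measured step bears on this, an at least 4.6-fold lower number from compound 1 to compound 2 (0.66 log units; beyond the scatter), made on the same amine nitrogen. That step shows that a change here can move the number in this assay. However, it replaces a whole group rather than adding an atom to one, so it gives no direct size for the new change. A modest shift toward a lower number is expected, though a change within the scatter remains possible. The expected change is a 1.7-fold lower number from compound 2 to compound 3 (0.24 log units; within the scatter). For compound 3 the estimated value is 1000 nM, with an expected range of 280 nM to 3500 nM.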

Compound 3, half-maximal inhibitory concentration: 1400 nM
Compound 3: the middle estimate sits 1.4-fold (0.15 log units) below what was measured; the range from low to high includes it.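

In this assay, turning phenyl into 4-iodophenyl gives a 1.2-fold lower number from compound 2 to compound 3 (0.09 log units; within the scatter), so an iodine at this place on the ring leaves the two compounds indistinguishable. The earlier contrast with cyclohexyl also holds for this second aromatic ring, with an at least 5.7-fold lower number from compound 1 to compound 3 (0.75 log units; beyond the scatter). Compound 1 stands at a limit of the assay and not a number, so that step gives only a minimum size: the limit of > 8000 nM in this assay, at which 1 of the 3 values shown sits.

Iodo is the only substituent shown on this ring and appears at only one place on it, so it remains open whether moving it would change the number. Going by these compounds, it also remains open whether a different group here, such as methoxy, an amine or a carboxylic acid, would move the number beyond the scatter.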